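This account rests on a few compounds, and the source may have more. Where it says the series, first, only, none or still open, it means among the compounds named here.

Measured in a functional assay on PC-3 cells (Homo sapiens) for inhibition, read by sulforhodamine B assay, with a stated time of 48 h; on this read-out lower numbers stand for stronger inhibition of growth and higher numbers for weaker inhibition of growth:
- Compound 1 `CCOC(=O)c1nn(-c2ccc(Cl)cc2)c(-c2ccc(OC)cc2)c1CNC(C)(C)C`: 210000 nM; > 523000 nM (2 entries)
- Compound 2 `COc1ccc(-c2c(CNC(C)(C)C)c(C(=O)O)nn2-c2ccccc2)cc1`: > 659000 nM
- Compound 3 `CC(C)(C)NCc1c(C(=O)O)nn(-c2ccc(Cl)cc2)c1-c1ccc(Br)cc1`: > 542000 nM

Compound 3 is known only through a limit of the assay, > 542000 nM, and not through a number. Compound 2 is also known only through a limit, > 659000 nM. Compound 1 is the only one of the three with a real number among its entries, which read (the several entries of compound 1 in this assay, 210000 nM; > 523000 nM (2 entries)); the entries with a sign are limits.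

Compound 4 `COc1ccc(-c2c(CNC(C)(C)C)c(C(=O)O)nn2-c2ccc(Cl)cc2)cc1` differs from compound 3 in one place: methoxy in place of bromo on an aromatic carbon, para to a large group. The counted change is methoxy in place of bromo on an aromatic carbon. Among the compounds with values here, no measured pair shows this change alone, so its effect cannot be read directly.

Compound 2 also carries the 4-methoxyphenyl group and reaches only a limit, > 659000 nM. On that basis, no change beyond the scatter is expected in this assay, and compound 4 will probably be reported as a limit rather than a number. The expected step is a step that the limit leaves unreadable from compound 3 to compound 4. For compound 4 the estimated value is 600000 nM, with an expected range from 300000 nM to 700000 nM.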

Compound 4, concentration for 50% growth inhibition: > 605000 nM
Compound 4 gave a limit, no number; the forecaster's own chance of this, stated with the estimate: 85%; middle value at least 1.0-fold (0.00 log units) from the limit.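

Compound 4 reads > 605000 nM in this assay and this is a limit, not a number. Compound 2 and compound 3 are also known only through limits, so the steps from each of them to compound 4 cannot be read. On these data alone, whether methoxy in place of bromo, or chloro in place of hydrogen, changes growth inhibition at all remains open.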